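A Two-Ring Group Replaces a Halogenated Phenyl

The source may hold more compounds than are shown below. What is called first, only, known or untested is meant among the compounds shown, and "the series" means these compounds.

Of the compounds shown here, three built on one shared core have been tested in an assay on CHO cells for displacement of a labelled ligand from adenosine receptor A3 (Homo sapiens), read by scintillation counting, with a stated time of 120 min, tested at 10 uM; a lower number here means less inhibition, a higher number more inhibition at the concentration tested (going by the name of the read-out). Compound 1 `Nc1scc(CN2CCN(c3ccc(F)cc3Cl)CC2)c1C(=O)c1ccc(Cl)cc1` gives 0%, compound 2 `Nc1scc(CN2CCN(c3ccc(Cl)cc3F)CC2)c1C(=O)c1ccc(Cl)cc1` gives 1%, and compound 3 `Nc1scc(CN2CCN(c3ccccc3C(F)(F)F)CC2)c1C(=O)c1ccc(Cl)cc1` gives 0%. Compound 1 is level with compound 3, and together they are the lowest of the three numbers; the step of a number 1 percentage points higher from compound 1 to compound 2 (within the scatter) and the step of no change at the digits printed from compound 1 to compound 3 (within the scatter) both lie within the scatter. Compound 4 `Nc1scc(CN2CCN(c3cccc4ccccc34)CC2)c1C(=O)c1ccc(Cl)cc1` differs from compound 1 in one place: naphthalen-1-yl in place of 2-chloro-4-fluorophenyl on an amine nitrogen in a ring. The measured steps only exchange one substituted phenyl for another on the same ring nitrogen, and none moved the read-out beyond the scatter, so there is little guide for a change to a two-ring group. Compound 4 is therefore expected to stay near the others, with a step of a number 5 percentage points higher from compound 1 to compound 4 (within the scatter), giving an estimate of 5%, between 0% and 30%.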

Compound 4, a percentage reported as inhibition, at one concentration (the size of the read-out at that concentration, not a potency): 0%
Beside the measured number, compound 4's estimate is 5 percentage points above it; low and high end bracket the measured number.
By their numbers in this assay, from the lowest: compounds 1, 3, 4 and 2 (each within the scatter of the next).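

In this assay the change to naphthalen-1-yl shows no change at the digits printed from compound 1 to compound 4 (within the scatter) and no change at the digits printed from compound 3 to compound 4 (within the scatter) and also a number 1 percentage points lower from compound 2 to compound 4 (within the scatter) at this ring nitrogen. The read-out therefore stays flat even when a phenyl ring gives way to two aromatic rings of carbon only, which the swaps from one substituted phenyl to another could not show. Nothing available offers an explanation for this flat result. From the compounds shown here alone, it remains open whether a different kind of group on this nitrogen, such as a pyridine ring, a benzyl group or a simple alkyl chain, would raise the inhibition. Going by these compounds, the effect of replacing the 4-chlorophenyl on the carbonyl is also open.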